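The source may report more compounds than this note shows. Statements on the series, on what has been measured and on what is new or still open speak of the compounds shown alone.

Of the compounds shown here, two from this series have been measured in an ADME assay on microsomes (Homo sapiens) for metabolic stability; on this read-out higher numbers stand for a longer-lived compound and lower numbers for a shorter-lived compound. Compound 1 `O=C1c2cc(-c3ccc(OC(F)(F)F)cc3)ccc2OCCN1Cc1ncccn1` gives 6.58 h in this assay. Compound 2 `O=C1c2cc(-c3ccc(OC(F)(F)F)cc3)ccc2CCN1Cc1ncccn1`, which shares the same trifluoromethoxy-bearing aryl group and the same pyrimidinylmethyl amide but differs in the shared core, gives 6.58 h in this assay. On the numbers shown, compound 2 stands level with compound 1 at the digits reported, and the two values lie within the scatter of each other, so nothing can be said of an order between them.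

The next compound, compound 3 `O=C1c2cc(-c3ccc(C(F)(F)F)cc3)ccc2CCN1Cc1ncccn1`, keeps the core of compound 2 and alters only the substituent on the distal aromatic ring: trifluoromethyl in place of trifluoromethoxy on an aromatic carbon. Going by the values given here, no step between two measured compounds covers this kind of change, so the expectation for compound 3 rests on the stability of compound 2 alone. Given the value of compound 2 at 6.58 h, the step from compound 2 to compound 3 in this assay is expected to be a 1.0-fold lower number from compound 2 to compound 3 (0.02 log units; within the scatter), that is, no change beyond the scatter in either direction. Compound 3 is therefore estimated at 6.3 h, with a likely range from 3.3 h to 12 h.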

Compound 3, half-life in the Homo sapiens assay: 5.07 h
For compound 3 the middle estimate is 1.2-fold (0.09 log units) above the measured one; low and high end bracket the measured number.
By their numbers in the Homo sapiens assay, from the lowest: compounds 3, 1 and 2 (each within the scatter of the next).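

In the Homo sapiens assay the change to trifluoromethyl in place of trifluoromethoxy on an aromatic carbon, para to a large group, gives a 1.3-fold lower number from compound 2 to compound 3 (0.11 log units; within the scatter) and so leaves the half-life with no change that can be told from the scatter. The same change does register in a physicochemical assay for solubility (a higher number here means a more soluble compound, a lower number a less soluble compound), where compound 2 gives 60000 nM and compound 3 gives 28000 nM in a step that reads a 2.1-fold lower number from compound 2 to compound 3 (0.33 log units; beyond the scatter) and counts as a modest one. At this position, then, the change shows up in solubility and not in half-life, a reading that rests on this single pair: the measured solubility of compound 2, 60000 nM, and of compound 3, 28000 nM, a 2.1-fold lower number (0.33 log units; beyond the scatter).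

These compounds leave open whether the same change on the core of compound 1 would give the same two results. They also leave open how other groups at this position, such as a nitrile, a methoxy group or an amine, would stand in half-life or in solubility.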